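Phenyl to 2-chlorophenyl at compound 2

A few compounds are considered here, and "the series" means these few. Any claim that something is new, unique, unknown or untested is made for them only; others in the source may bear on it.

Measured in a functional assay on HepG2 cells (Homo sapiens) for antiproliferative activity, read by CCK-8 assay, with a stated time of 48 h; a higher number here means a weaker inhibitor, a lower number a stronger inhibitor:
- compound 1 `O=C(CCCCCOc1cccc(-c2nnc(-c3ccccc3)s2)c1)NO`: 1400 nM
- compound 2 `O=C(CCCCCCOc1cccc(-c2nnc(-c3ccccc3)s2)c1)NO`: 2200 nM

In this assay compound 2 gives 2200 nM, within the scatter of compound 1. Compound 3 `O=C(CCCCCCOc1cccc(-c2nnc(-c3ccccc3Cl)s2)c1)NO` keeps the chain of compound 2 and changes the ring: chloro in place of hydrogen on an aromatic carbon. Going by the values given here, the only measured step, a 1.6-fold higher number from compound 1 to compound 2 (0.20 log units; within the scatter), lies in the chain and within the scatter, so it says little about this ring change. Among the compounds with values here, no measured step covers chloro, so no shift beyond the scatter is expected, and no direction can be assigned. The expected change is a 1.1-fold lower number from compound 2 to compound 3 (0.04 log units; within the scatter). Compound 3 is expected at 2000 nM, with an estimated range of 800 nM to 5000 nM.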

Compound 3, half-maximal inhibitory concentration: 21000 nM
Estimate against measurement, compound 3: 11-fold (1.02 log units) below; measured number above the stated range.
By their numbers in this assay, from the lowest: compounds 1 and 2 (each within the scatter of the next); then compound 3.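

In this assay, chloro in place of hydrogen on an aromatic carbon, ortho to a large group, gives a 9.5-fold higher number from compound 2 to compound 3 (0.98 log units; beyond the scatter) and so weakens the series at this position. The chain change between compound 1 and compound 2 stays within the scatter, whereas this single chlorine moves the number beyond it, so this ring position responds to substitution.

Open, on these data alone, is whether fluoro or methyl at this same carbon costs as much. Also open, as far as these compounds go, is whether chloro has the same effect on the chain of compound 1.

No measurement here accounts for the loss.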